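Fluoro in place of hydrogen: compound 1 to compound 4

The source may report more compounds than this note shows. Statements on the series, on what has been measured and on what is new or still open speak of the compounds shown alone.

Measured so far in a functional assay on HeLa cells (Homo sapiens) for antiproliferative activity, read by MTT assay, with a stated time of 72 h; on this read-out higher numbers stand for weaker inhibition and lower numbers for stronger inhibition:
compound 1, `O=C1COc2ccc(-c3cccc(NS(=O)(=O)c4ccc(F)cc4)c3)cc2N1c1ccccc1`, gives 17700 nM.
compound 3, `COc1ncc(-c2ccc3c(c2)N(c2ccc(Cl)cc2)C(=O)CO3)cc1NS(=O)(=O)c1ccc(F)cc1`, gives 4830 nM.
compound 2, `O=C1COc2ccc(-c3cnc4ccccc4c3)cc2N1c1ccccc1`, reaches only the assay limit of > 40000 nM, which is a limit and not a number.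

Among the two numbers recorded, compound 1 carries the higher one; compound 3 sits below it by a gap beyond the usual scatter. One of the three entries is a limit rather than a number, in line with the limit of > 40000 nM in this assay, at which 1 of the 3 values shown sits. Among the compounds with values here, compound 3 differs from compound 1 in more than one place, so no single step between measured compounds is available.

Compound 4, `O=C1COc2ccc(-c3cccc(NS(=O)(=O)c4ccc(F)cc4)c3)cc2N1c1ccc(F)cc1`, is the next entry. Against compound 1 it shows (fluoro in place of hydrogen on an aromatic carbon). With no measured step of this kind in hand, the expectation for this assay is a small move, if any, toward a lower number, within the scatter. On that basis compound 4 is estimated at 12000 nM, with a range from 5000 nM to 30000 nM, which corresponds to an expected step of a 1.5-fold lower number from compound 1 to compound 4 (0.17 log units; within the scatter).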

Compound 4, half-maximal inhibitory concentration: > 40000 nM
Compound 4: a limit, no number (the forecaster's own chance of this, stated with the estimate: 5%); at least 3.3-fold (0.52 log units) between middle value and limit.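

In this assay, within the data shown here, the change from phenyl to 4-fluorophenyl gives an at least 2.2-fold higher number from compound 1 to compound 4 (0.35 log units; beyond the scatter) and provides the first single-place step. At this place, para to a large group, adding 1 heavy atom to the shared core is enough to carry the result beyond the scatter, and the direction is toward weaker inhibition. Compound 4 gives a limit and not a number, so the step has only a lower bound, and this limit is not unique in the series: the limit of > 40000 nM in this assay, at which 2 of the 4 values shown sit.

Going by these compounds, whether an amine or a methyl group at this place would behave like fluoro remains open. Compound 3 carries 4-chlorophenyl but differs from compound 1 in more than one place, so it cannot show how chloro compares at this position.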